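The source may hold more compounds than are shown below. What is called first, only, known or untested is meant among the compounds shown, and "the series" means these compounds.

Compound 1 `Nc1ccccc1NC(=O)c1ccc(CNC2=NC(=O)C(Cc3c[nH]c4ccccc34)N2)cc1` was tested in an assay for inhibition of histone deacetylase 8 (Homo sapiens), read by fluorescence, with stated times of 15 min and 60 min; a higher number here means a weaker inhibitor, a lower number a stronger inhibitor. In this assay compound 1 gives only a limit, > 20000 nM, that is the limit of > 20000 nM in this assay, at which 1 of the 2 values shown sits. Compound 2 `Nc1ccccc1NC(=O)c1ccc(CNC2=NC(=O)C(Cc3ccccc3)N2)cc1` gives in this assay 13000 nM. For the measured compounds named here, the one measured step, an at least 1.5-fold lower number from compound 1 to compound 2 (0.18 log units; that floor lies within the scatter), stays within the scatter. Going by the values given here, compound 3 `CC(=O)N1C(NCc2ccc(C(=O)Nc3ccccc3N)cc2)=NC(=O)C1Cc1c[nH]c2ccccc12` carries acetyl in place of hydrogen on an amine nitrogen in a ring, acetyl in place of hydrogen on an amine nitrogen in a ring, two ring bonds from the ring nitrogen; no measured step bears on that change. Compound 3 is therefore expected to give about 20000 nM, between 5000 nM and 60000 nM, an expected step of a number no higher from compound 1 to compound 3 (the limit leaves the size open).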

Compound 3, half-maximal inhibitory concentration: 24300 nM
Compound 3: middle estimate off by 1.2-fold (0.08 log units), on the low side, within the range that was stated.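

For the compounds shown here, no step from compound 1 to compound 3 can be read, because compound 1 gives only a limit: the limit of > 20000 nM in this assay, at which 1 of the 3 values shown sits. The compounds shown leave open whether acetyl in place of hydrogen on an amine nitrogen in a ring changes the number at all.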